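Aryl amide swap in the cinnamyl series: compound 3 to 4

This account rests on a few compounds, and the source may have more. Where it says the series, first, only, none or still open, it means among the compounds named here.

Values in a functional assay on A549 cells (Homo sapiens) for inhibition, read by MTT assay, with a stated time of 72 h; on this read-out higher numbers stand for weaker inhibition and lower numbers for stronger inhibition:
- compound 1 `Cc1ccc(NC(=O)C2CCN(C/C=C/c3ccccc3)CC2)cc1`: 29600 nM
- compound 2 `CCCc1ccc(NC(=O)C2CCN(C/C=C/c3ccccc3)CC2)cc1`: 9470 nM
- compound 3 `O=C(Nc1cccc(Br)c1)C1CCN(C/C=C/c2ccccc2)CC1`: 16500 nM

Compound 3 falls inside the span set by compound 1 and compound 2, within the scatter of each: a 1.8-fold lower number from compound 1 to compound 3 (0.25 log units; within the scatter) and a 1.7-fold higher number from compound 2 to compound 3 (0.24 log units; within the scatter). The next structure is compound 4 `O=C(Nc1nccs1)C1CCN(C/C=C/c2ccccc2)CC1`, with 1,3-thiazol-2-yl in place of 3-bromophenyl on an amide-type nitrogen. Among the measured compounds shown here, those two steps changed the group on the same nitrogen and stayed within the scatter, but neither brought in a ring with hetero atoms, so this swap has no direct precedent in the data. For the measured compounds named here, the only step beyond the scatter, a 3.1-fold lower number from compound 1 to compound 2 (0.49 log units; beyond the scatter), was modest and extended a chain on the ring. A small move toward a higher number is therefore expected in this assay, probably not clearing the scatter: a 1.6-fold higher number from compound 3 to compound 4 (0.20 log units; within the scatter). For compound 4 the estimated value is 26000 nM, with an expected range of 10000 nM to 60000 nM.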

Compound 4, half-maximal inhibitory concentration: 34900 nM
The estimate for compound 4 lay 1.3-fold (0.13 log units) below the measured number; measured number inside the range.
By their numbers in this assay, from the lowest: compounds 2, 3, 1 and 4 (each within the scatter of the next, the first and the last beyond it).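

Moving to 1,3-thiazol-2-yl on the amide-type nitrogen, the first ring with hetero atoms at this place, gives a 2.1-fold higher number from compound 3 to compound 4 (0.33 log units; beyond the scatter) in this assay and so clears the scatter, where the earlier swaps of aryl group on this nitrogen did not. The step of a 3.7-fold higher number from compound 2 to compound 4 (0.57 log units; beyond the scatter) is also beyond the scatter, whereas a 1.2-fold higher number from compound 1 to compound 4 (0.07 log units; within the scatter) stays within it, so compound 4 and compound 1 cannot be told apart and none of the three steps goes to a lower number. No measurement at hand accounts for these steps.

Still open, as far as these compounds go, is how an unsubstituted phenyl or a pyridin-2-yl ring would read on this nitrogen. Also open, from the compounds shown here alone, is whether a propyl chain on the 1,3-thiazol-2-yl ring would lower the number, as the longer chain did on the phenyl ring of compound 2.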